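This account rests on a few compounds, and the source may have more. Where it says the series, first, only, none or still open, it means among the compounds named here.

Compound 3 `Cc1cc(C(=O)Nc2cc(CC(=O)O)ccc2Cl)c(C)cc1OC[C@@H]1CN(C)c2ccccc2O1` pairs a chloro group on the amide-bearing ring with a carboxymethyl acid. In a functional assay on CHO cells for antagonist activity at prostaglandin D2 receptor (Mus musculus), read by cAMP accumulation and immunoassay, with a stated time of 10 min (a lower number here means a stronger inhibitor, a higher number a weaker inhibitor), compound 3 gives 5.1 nM. That is the lowest of the two numbers recorded, but its nearest neighbour is compound 1 `Cc1ccc(CC(=O)O)cc1NC(=O)c1cc(C)c(OC[C@@H]2CN(C)c3ccccc3O2)cc1C`, which in this assay gives 5.7 nM, and the step of a 1.1-fold lower number from compound 1 to compound 3 (0.05 log units; within the scatter) lies within the scatter, so the two cannot be ordered. Compound 2 `Cc1cc(OC[C@@H]2CN(C)c3ccccc3O2)ccc1C(=O)Nc1cc(CC(=O)O)ccc1Cl` has in this assay only "not determined" (no result reported), and nothing can be said of it.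

Compound 4 `Cc1cc(C(=O)Nc2cc(C(C)(C)C(=O)O)ccc2Cl)c(C)cc1OC[C@@H]1CN(C)c2ccccc2O1` differs from compound 3 in one place: 1-carboxy-1-methylethyl in place of carboxymethyl on an aromatic carbon. The new group sits on an aromatic carbon of a six-membered aromatic ring of carbon only, meta to a large group and para to a chloro group. Among the measured compounds shown here, no measured step touches the acid side chain; the only step recorded concerns the chloro-for-methyl exchange on the same ring and was within the scatter, so it gives no guidance here. With nothing to anchor it, the expectation is a small shift toward a weaker number and a wide range. Compound 4 is therefore estimated in this assay at 12 nM, between 3 nM and 50 nM. The step of a 2.4-fold higher number from compound 3 to compound 4 (0.37 log units; beyond the scatter) is expected to be modest.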

Compound 4, half-maximal inhibitory concentration: 43 nM
Compound 4: the middle estimate sits 3.6-fold (0.55 log units) below what was measured, and the stated range covers the measured number.
By their numbers in this assay, from the lowest: compounds 3 and 1 (each within the scatter of the next); then compound 4.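

Among the compounds shown here, compound 4 gives the first reading on the acid side chain, the group on the aromatic carbon meta to a large group and para to a chloro group: in this assay, 1-carboxy-1-methylethyl in place of carboxymethyl gives an 8.4-fold higher number from compound 3 to compound 4 (0.93 log units; beyond the scatter), a step beyond the scatter. The earlier exchange of chloro for methyl, a 1.1-fold lower number from compound 1 to compound 3 (0.05 log units; within the scatter), lay within the scatter, so among the compounds shown this side-chain change is the one that separates two numbers, even though the two groups match in hydrogen-bond donors, hydrogen-bond acceptors and net charge and differ in heavy atoms, 4 against 6. No measurement presented here explains the rise in the number.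

The compounds shown do not tell whether 1-carboxyethyl, with a single methyl on the carbon bearing the acid, would stand with compound 3 or with compound 4, or how a carboxylic acid set directly on the ring or a longer chain such as 2-carboxyethyl would compare. They also leave open whether the same exchange would give a step of similar size with methyl in place of chloro on that ring, as in compound 1.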